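Methyl on the ring nitrogen of a symmetric bis-benzylidene core

A few compounds are considered here, and "the series" means these few. Any claim that something is new, unique, unknown or untested is made for them only; others in the source may bear on it.

Compound 1 `COc1ccccc1/C=c1/[nH]c(=O)/c(=C\c2ccccc2OC)[nH]c1=O` is reported as "not active" (no number reported) in a functional assay on Huh-7 cells (Homo sapiens) for cytotoxicity, read by CCK-8 assay, with a stated time of 72 h; on this read-out higher numbers stand for weaker inhibition and lower numbers for stronger inhibition. Compound 2 `C=CCn1c(=O)/c(=C\c2cccc(Cl)c2)[nH]c(=O)/c1=C\c1ccccc1OC`, which carries a different substituent pattern, gives 8900 nM in this assay. Compound 3 `COc1ccccc1/C=c1/[nH]c(=O)/c(=C\c2ccccc2OC)n(C)c1=O` differs from compound 1 by methyl in place of hydrogen on an aromatic nitrogen. Going by the values given here, with no measured step of this kind available, the size of the step cannot be read from the data; compound 2 offers the only hint that substitution on a ring nitrogen is compatible with measurable inhibition, so a gain beyond the scatter is expected, though a modest one. Compound 3 is therefore estimated at 15000 nM, within 5000 nM to 60000 nM.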

Compound 3, half-maximal inhibitory concentration: "not active" (no number reported)
Nothing numeric was reported for compound 3; the estimate stays without a comparison.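

Neither compound 1 nor compound 3 has a reported number, so no step can be read for methyl in place of hydrogen on the aromatic nitrogen. The compounds shown leave open whether this methyl alters inhibition at all. No measurement here offers an explanation.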